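This account rests on a few compounds, and the source may have more. Where it says the series, first, only, none or still open, it means among the compounds named here.

Measured so far, in a functional assay on MGC-803 cells (Homo sapiens) for antiproliferative activity, read by MTT assay, with a stated time of 48 h; a higher number here means a weaker inhibitor, a lower number a stronger inhibitor: compound 1 `Cc1ccc(NC(=O)Nc2cccc(CNc3nccnc3Cl)c2)cc1` gives 11900 nM; compound 2 `Cc1ccc(NC(=O)Nc2cccc(CNc3nccnc3Cl)c2)cc1Cl` gives 17500 nM; compound 3 `O=C(Nc1cccc(CNc2nccnc2Cl)c1)Nc1ccc(Cl)cc1Br` gives 7480 nM.

Among these three, compound 3 has the lowest number, though its gap to compound 1 lies within the scatter and only a 2.3-fold lower number from compound 2 to compound 3 (0.37 log units; beyond the scatter) stands beyond it. Compound 4 `O=C(Nc1cccc(CNc2nccnc2Cl)c1)Nc1ccc(Cl)c(Cl)c1` differs from compound 3 in one place: 3,4-dichlorophenyl in place of 2-bromo-4-chlorophenyl on an amide-type nitrogen. Among the compounds with values here, the steps that bear on this change are those that also swapped the aryl group on the amide-type nitrogen, a 1.6-fold lower number from compound 1 to compound 3 (0.20 log units; within the scatter) and a 2.3-fold lower number from compound 2 to compound 3 (0.37 log units; beyond the scatter), together with a 1.5-fold higher number from compound 1 to compound 2 (0.17 log units; within the scatter), where a chloro was added. All were small. For compound 4 a step of a 1.3-fold higher number from compound 3 to compound 4 (0.13 log units; within the scatter) in this assay is therefore expected, within the scatter, giving an estimated 10000 nM, ranging from 5000 nM to 20000 nM.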

Compound 4, half-maximal inhibitory concentration: 4970 nM
Beside the measured number, compound 4's estimate is 2.0-fold (0.30 log units) above it; measured number below the stated range.
By their numbers in this assay, from the lowest: compounds 4, 3, 1 and 2 (each within the scatter of the next, the first and the last beyond it).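

In this assay, within the data shown here, 3,4-dichlorophenyl on the amide-type nitrogen is the first group here to stand beyond the scatter of both methyl-bearing compounds, with a 3.5-fold lower number from compound 2 to compound 4 (0.55 log units; beyond the scatter) for chloro in place of methyl and a 2.4-fold lower number from compound 1 to compound 4 (0.38 log units; beyond the scatter) for the swap from 4-methylphenyl. Against 2-bromo-4-chlorophenyl the change gives only a 1.5-fold lower number from compound 3 to compound 4 (0.18 log units; within the scatter) so these two groups cannot be told apart here. Nothing available explains these steps.

On these data alone, what an amine or a carboxylic acid on this phenyl ring would do stays open, as does the effect of a single chloro group on its own.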